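From Methylurea to Methyl Carbamate: Expected Microsomal Stability

A few compounds are considered here, and "the series" means these few. Any claim that something is new, unique, unknown or untested is made for them only; others in the source may bear on it.

compound 1, `CC(C)(C)CNCCS(=O)(=O)NC(=O)c1ccc(Nc2nc(NC3(c4ccc(Cl)cc4)CC3)nc(OCC(F)(F)F)n2)cc1`: 89%
compound 2, `CNC(=O)NCCS(=O)(=O)NC(=O)c1ccc(Nc2nc(NC3(c4ccc(Cl)cc4)CC3)nc(OCC(F)(F)F)n2)cc1`: 97%

The two measured compounds share one core and differ only in the group on an amine nitrogen of the side chain. In an ADME assay on microsomes from liver (Homo sapiens) for metabolic stability, with a stated time of 10 min (on this read-out higher numbers stand for a more stable compound and lower numbers for a less stable compound), compound 1 gives 89% and compound 2 gives 97%. The step of a number 8 percentage points higher from compound 1 to compound 2 (within the scatter) lies within the scatter, so the two numbers cannot be told apart. Compound 2 thus stands level with compound 1 on this read-out, and both leave most of the compound intact after the stated time.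

Compound 3, `COC(=O)NCCS(=O)(=O)NC(=O)c1ccc(Nc2nc(NC3(c4ccc(Cl)cc4)CC3)nc(OCC(F)(F)F)n2)cc1`, has not been measured. Its change from compound 2 is methoxy in place of methylamino on a carbonyl carbon. Read one bond further out, a methylcarbamoyl group becomes a methoxycarbonyl group, so the (methylcarbamoyl)amino chain becomes a (methoxycarbonyl)amino chain. Within the data shown here, no measured step covers this exchange. Among the measured compounds shown here, the only measured step, from neopentyl to methylcarbamoyl, concerns a different part of the chain and was itself within the scatter. With both measured compounds largely intact and no step beyond the scatter among them, no shift beyond the scatter is expected in this assay. Compound 3 is therefore expected to give 90%, with a range from 75% to 99%. The expected step of a number 7 percentage points lower from compound 2 to compound 3 (within the scatter) is small.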

Compound 3, percent of the compound remaining: 90%
Estimate against measurement, compound 3: no gap at the digits printed; low and high end bracket the measured number.
By their numbers in this assay, from the lowest: compounds 1, 3 and 2 (each within the scatter of the next).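

In this assay, replacing methylamino with methoxy on a carbonyl carbon gives a number 7 percentage points lower from compound 2 to compound 3 (within the scatter), so trading the hydrogen-bond donor of the urea-type chain for the hydrogen-bond acceptor of the carbamate-type chain leaves no readable mark on this number. Among these compounds, the comparison with the neopentyl compound gives a number 1 percentage points higher from compound 1 to compound 3 (within the scatter), which means that neopentyl, methylcarbamoyl and methoxycarbonyl on this amine nitrogen now form a set of three that cannot be told apart here, where the earlier pair could speak for only two groups. Nothing measured on these compounds offers an explanation for this levelness, so it stands as an observation only.

The compounds shown leave open whether any other group on this carbonyl carbon, such as an ethoxy group, a dimethylamino group or a longer chain, would move the number beyond the scatter, and whether a free amine or a carboxylic acid at the end of the chain would do so. They also leave open whether the three compounds would stay level after a longer time in the microsomes, since all of them remain largely intact at the stated time.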